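A Methoxyphenyl Thiosemicarbazone Awaits Its Antiproliferative Reading

This account rests on a few compounds, and the source may have more. Where it says the series, first, only, none or still open, it means among the compounds named here.

In a functional assay on SGC-7901 cells (Homo sapiens) for antiproliferative activity, read by sulforhodamine B assay, with a stated time of 72 h (on this read-out higher numbers stand for weaker inhibition and lower numbers for stronger inhibition), compound 1 `FC(F)(F)c1ccccc1NC(=S)N/N=C/c1ccc2ccccc2n1` gives 20700 nM. Compound 2 `Fc1ccccc1NC(=S)N/N=C/c1ccc2ccccc2n1` stops at the assay limit of > 100000 nM in this assay. Compound 3 `NC(=S)N/N=C/c1cnc2ccccc2n1` likewise stops at the limit of > 100000 nM. Compound 2 thus sits at the limit of > 100000 nM in this assay, at which 2 of the 3 values shown sit, and has no number of its own. For the measured compounds named here, the only measured step on the group attached to the amide-type nitrogen is an at least 4.8-fold higher number from compound 1 to compound 2 (0.68 log units; beyond the scatter). Compound 4 `COc1ccc(NC(=S)N/N=C/c2ccc3ccccc3n2)cc1` carries 4-methoxyphenyl in place of 2-fluorophenyl on an amide-type nitrogen. Going by the values given here, no measured step matches this change. For compound 4 the expected step of an at least 1.4-fold lower number from compound 2 to compound 4 (0.15 log units; that floor lies within the scatter) therefore rests on little. Compound 4 is expected to give about 70000 nM, between 15000 nM and 300000 nM, with a real chance that this assay again reports only a limit.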

Compound 4, half-maximal inhibitory concentration: 89600 nM
For compound 4 the middle estimate is 1.3-fold (0.11 log units) below the measured one; the range from low to high includes it.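

In this assay compound 4 gives a number of its own at this amide-type nitrogen, so a 4-methoxyphenyl group here leaves a value that can be read. The change itself reads as an at least 1.1-fold lower number from compound 2 to compound 4 (0.04 log units; that floor lies within the scatter), which does not establish any real difference between the two groups. Compound 2 has only a limit, not a number, so the true size of the step stays unknown: the limit of > 100000 nM in this assay, at which 2 of the 4 values shown sit.

The compounds shown leave open how a phenyl ring carrying an amine or a carboxylic acid would read at this nitrogen. They also leave open whether an unsubstituted phenyl would give a measurable value.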